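Swapping the aromatic acid for a flexible acid chain

The source may report more compounds than this note shows. Statements on the series, on what has been measured and on what is new or still open speak of the compounds shown alone.

Going by the values given here, compound 2 `CC(C)=CCCC1=CC[C@@H](C(=O)Nc2ccc(C(=O)O)cc2)[C@H](c2ccccc2)C1` is the only compound here with a number rather than a limit: in an assay on isolated protein for inhibition of Apoptosis regulator Bcl-2 (Homo sapiens), read by fluorescence polarization, with stated times of 5 min and 10 min (a lower number here means a stronger inhibitor, a higher number a weaker inhibitor), compound 2 gives 2200 nM. Compound 1 `CC(C)=CCCC1=CC[C@@H](C(=O)N(C)C)[C@H](c2ccccc2)C1` reaches only a limit of the assay, and in this assay compound 1 gives > 23000 nM. Among the compounds with values here, the single measured step, (4-carboxyphenyl)amino in place of dimethylamino on the carbonyl carbon, gave an at least 10-fold lower number from compound 1 to compound 2 (1.01 log units; beyond the scatter), although one end of that step is the limit of > 23000 nM in this assay, at which 1 of the 2 values shown sits, and not a number. Compound 3 `CC(C)=CCCC1=CC[C@@H](C(=O)NCCC(=O)O)[C@H](c2ccccc2)C1` differs from compound 2 by 2-carboxyethyl in place of 4-carboxyphenyl on an amide-type nitrogen. Within the data shown here, the acid stays but the ring leaves; no measured step tests such a change, so the only guide is that adding the carboxyphenyl group was the move that produced a number. The estimate for compound 3 is therefore a weaker binder, 8000 nM with a range of 3000 nM to 25000 nM. That corresponds to an expected step of a 3.6-fold higher number from compound 2 to compound 3 (0.56 log units; beyond the scatter).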

Compound 3, inhibition constant: > 23000 nM
Compound 3: a limit, no number (the forecaster's own chance of this, stated with the estimate: 30%); middle value at least 2.8-fold (0.45 log units) from the limit.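

With the carboxylic acid kept and only the ring gone, 2-carboxyethyl in place of 4-carboxyphenyl gives an at least 10-fold higher number from compound 2 to compound 3 (1.01 log units; beyond the scatter). On this amide-type nitrogen, then, an acid alone does not preserve a measurable number in this assay, and the gain seen with 4-carboxyphenyl depends on more than the acid. Compound 3 and compound 1 cannot be ordered against each other, and the step between them cannot be read, as both stand at a limit of the assay rather than at a number: the limit of > 23000 nM in this assay, at which 2 of the 3 values shown sit.

A plain phenyl group on the same nitrogen would show whether the ring can give binding without the carboxylic acid. A longer chain ending in a carboxylic acid would show whether the loss depends on chain length or on the absence of a ring.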